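A few compounds are considered here, and "the series" means these few. Any claim that something is new, unique, unknown or untested is made for them only; others in the source may bear on it.

In an assay on isolated protein for inhibition of aldehyde dehydrogenase 1A1 (Homo sapiens), read by spectrophotometry, tested at 10 uM (a higher number here means more inhibition at the concentration tested (going by the name of the read-out), a lower number less inhibition), compound 1 `Cc1cccc(Cn2c(CN3CCN(C(=O)C4CCCC4)CC3)nc3ccccc32)c1` gives 67.5%, compound 2 `Cc1cccc(Cn2c(CN3CCN(C(=O)c4ccc(Cl)cc4)CC3)nc3ccccc32)c1` gives 23.2%, and compound 3 `Cc1ccc(C(=O)N2CCN(Cc3nc4ccccc4n3Cc3cccc(C)c3)CC2)cc1` gives 64.9%. Compound 3 stands second highest of the three: its gap to compound 1 is within the scatter, whereas a number 41.7 percentage points higher from compound 2 to compound 3 (beyond the scatter). Compound 4 `COc1ccc(C(=O)N2CCN(Cc3nc4ccccc4n3Cc3cccc(C)c3)CC2)cc1` differs from compound 3 by methoxy in place of methyl on an aromatic carbon. Among the compounds with values here, the measured steps that bear on this are a number 2.6 percentage points lower from compound 1 to compound 3 (within the scatter) and a number 41.7 percentage points higher from compound 2 to compound 3 (beyond the scatter), which show that the group on this aromatic carbon can matter greatly or hardly at all; no measured step tests methoxy itself. A step of modest size in this assay, most likely within the scatter and if anything downward, is expected, a number 6.9 percentage points lower from compound 3 to compound 4 (within the scatter). Compound 4 is therefore estimated at 58%, with an expected range from 35% to 78%.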

Compound 4, a percentage reported as inhibition, at one concentration (the size of the read-out at that concentration, not a potency): 55.5%
Compound 4: the middle estimate sits 2.5 percentage points above what was measured; low and high end bracket the measured number.
By their numbers in this assay, from the lowest: compound 2; then compounds 4, 3 and 1 (each within the scatter of the next, the first and the last beyond it).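

In this assay methoxy on the aromatic carbon para to a large group stays within the scatter of methyl (a number 9.4 percentage points lower from compound 3 to compound 4 (within the scatter)), and chloro remains the outlier at this place (a number 32.3 percentage points higher from compound 2 to compound 4 (beyond the scatter)). Against cyclopentyl, the 4-methoxyphenyl group gives a modest step beyond the scatter (a number 12 percentage points lower from compound 1 to compound 4 (beyond the scatter)), so an aryl group without chloro can also fall measurably short of compound 1. As far as these compounds go, whether an amine or a carboxylic acid at this aromatic carbon would behave like methoxy or like chloro remains open. Nothing available explains these steps.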